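The source may hold more compounds than are shown below. What is called first, only, known or untested is meant among the compounds shown, and "the series" means these compounds.

Compound 2 `C#Cc1cn([C@@H]2O[C@H](CO)[C@@H](O)[C@H]2O)c2ncnc(NC)c12` gives 86000 nM in an ADME assay on BJ cells (Homo sapiens), read by MTT assay, with a stated time of 72 h (on this read-out lower numbers stand for stronger inhibition and higher numbers for weaker inhibition), the lower of the two numbers on record, by a margin within the scatter. Its nearest neighbour, compound 1 `CSc1ncnc2c1c(-c1ccsc1)cn2[C@@H]1O[C@H](CO)[C@@H](O)[C@H]1O`, carries methylsulfanyl and gives 95800 nM in this assay. Compound 3 `C#Cc1cn([C@@H]2O[C@H](CO)[C@@H](O)[C@H]2O)c2ncnc(SC)c12` remains unmeasured in this assay. The change from compound 2 is methylsulfanyl in place of methylamino on an aromatic carbon. Going by the values given here, no step between measured compounds is available to size this change. Given the near-identical numbers of the two measured compounds, the step of a 1.0-fold higher number from compound 2 to compound 3 (0.02 log units; within the scatter) is expected, nothing beyond the scatter. Compound 3 is estimated at 90000 nM, within 40000 nM to 200000 nM.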

Compound 3, half-maximal inhibitory concentration: 68600 nM
Compound 3: the middle estimate sits 1.3-fold (0.12 log units) above what was measured; measured number inside the range.
By their numbers in this assay, from the lowest: compounds 3, 2 and 1 (each within the scatter of the next).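

In this assay, methylsulfanyl in place of methylamino on this aromatic carbon gives a 1.3-fold lower number from compound 2 to compound 3 (0.10 log units; within the scatter) and so loses the hydrogen-bond donor counted for methylamino without moving the number beyond the scatter. Ethynyl in place of thiophen-3-yl on an aromatic carbon gives a 1.4-fold lower number from compound 1 to compound 3 (0.15 log units; within the scatter) and so does not separate those two groups either. Nothing available gives a reason for either step. On these data alone, whether dimethylamino, methoxy or a longer chain such as ethylsulfanyl on this carbon would leave the scatter stays open.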